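A Larger Amino Group in Place of an Ether Linkage

The source may hold more compounds than are shown below. What is called first, only, known or untested is meant among the compounds shown, and "the series" means these compounds.

compound 1 `Fc1cc(-c2ccn3c(CC4CC4)nnc3c2Cl)ccc1NC1CC1`: 12.7 nM
compound 2 `Clc1cc(-c2ccn3c(CC4CC4)nnc3c2Cl)ccc1OC1CCOCC1`: 28.1 nM
compound 3 `FC(F)(F)c1c(-c2ccc(OC3CCOCC3)c(Cl)c2)ccn2c(CC3CC3)nnc12`: 12.3 nM

In an assay on cells for binding affinity to metabotropic glutamate receptor 2 (Homo sapiens), read by scintillation proximity assay (a higher number here means weaker binding, a lower number tighter binding), compound 3 gives 12.3 nM, the lowest of the three numbers. Compound 1 gives 12.7 nM, within the scatter of compound 3, while compound 2 gives 28.1 nM, beyond the scatter. Compound 4 `O[C@]1(C2CC2)CC[C@H](Nc2ccc(-c3ccn4c(CC5CC5)nnc4c3C(F)(F)F)cc2Cl)CC1` differs from compound 3 by (4-cyclopropyl-4-hydroxycyclohexyl)amino in place of (oxan-4-yl)oxy on an aromatic carbon. Within the data shown here, the only measured step, a 2.3-fold lower number from compound 2 to compound 3 (0.36 log units; beyond the scatter), alters a different group and does not bear directly on this exchange. Compound 1, which also carries an amino-linked ring, and compound 3 sit within the scatter of each other, though they differ in several places. Compound 4 is therefore expected to stay close to compound 3, with a 1.2-fold lower number from compound 3 to compound 4 (0.09 log units; within the scatter), nothing beyond the scatter. The estimate for compound 4 is 10 nM, between 3.5 nM and 30 nM.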

Compound 4, dissociation constant: 1.5 nM
Beside the measured number, compound 4's estimate is 6.7-fold (0.82 log units) above it, and the stated range ends above it.
By their numbers in this assay, from the lowest: compound 4; then compounds 3 and 1 (each within the scatter of the next); then compound 2.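

At the aromatic carbon ortho to a chloro group, this assay tolerates the larger (4-cyclopropyl-4-hydroxycyclohexyl)amino in place of (oxan-4-yl)oxy, with an 8.2-fold lower number from compound 3 to compound 4 (0.91 log units; beyond the scatter). Among these compounds, this is the first change at this position with the rest of the molecule held fixed, and it moves the number beyond the scatter. Nothing available here accounts for this gain.

The compounds shown leave open which part of the entering group carries the step: the amino link, the hydroxy group or the cyclopropyl ring. As far as these compounds go, whether an (oxan-4-yl)amino group on the same carbon gives a similar step also remains open.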